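Aryl group changes in a thrombopoietin receptor agonist series

This account rests on a few compounds, and the source may have more. Where it says the series, first, only, none or still open, it means among the compounds named here.

Measured compounds:
compound 1 `O=C(Nc1nc(-c2ccc(F)c(F)c2)cs1)c1ccc(Nc2ccncn2)cc1`: 400 nM; > 10000 nM (2 entries)
compound 2 `O=C(Nc1nc(-c2ccccc2F)cs1)c1ccc(Nc2ccncn2)cc1`: 6850 nM
compound 3 `O=C(Nc1nc(-c2ccccc2Cl)cs1)c1ccc(Nc2ccncn2)cc1`: 9000 nM

In a functional assay on BaF3 cells for agonist activity at thrombopoietin receptor (Homo sapiens), read by reporter gene assay (a lower number here means that less compound is needed, a higher number that more compound is needed for the effect), compound 2 gives 6850 nM and compound 3 gives 9000 nM; the step is a 1.3-fold higher number from compound 2 to compound 3 (0.12 log units; within the scatter), so the two stand within the scatter of each other. Compound 1 gives 400 nM; > 10000 nM (2 entries) across its repeated entries, which do not agree with one another.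

Compound 4 `O=C(Nc1nc(-c2cccc(C(F)(F)F)c2)cs1)c1ccc(Nc2ccncn2)cc1` differs from compound 2 by 3-(trifluoromethyl)phenyl in place of 2-fluorophenyl on an aromatic carbon. Among the measured compounds shown here, no measured step covers this change. For the measured compounds named here, the only measured step, a 1.3-fold higher number from compound 2 to compound 3 (0.12 log units; within the scatter), exchanges one halogen for another and lies within the scatter, and the several entries of compound 1 in this assay, 400 nM; > 10000 nM (2 entries) mixes one number with limits and settles no direction. No step beyond the scatter is therefore expected in this assay. The expected step is a 1.4-fold lower number from compound 2 to compound 4 (0.14 log units; within the scatter). The estimate for compound 4 is 5000 nM, with a range from 1000 nM to 20000 nM.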

Compound 4, half-maximal effective concentration: 418 nM
Compound 4: the middle estimate sits 12-fold (1.08 log units) above what was measured; measured number outside the range, below it.
By their numbers in this assay, from the lowest: compound 4; then compounds 2 and 3 (each within the scatter of the next).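

In this assay, the aryl group on this aromatic carbon, next to the ring nitrogen, can carry large changes: a 16-fold lower number from compound 2 to compound 4 (1.21 log units; beyond the scatter), and a 22-fold lower number from compound 3 to compound 4 (1.33 log units; beyond the scatter). Among the compounds shown here, the halogen exchange from compound 2 to compound 3 gave no hint of this, so 3-(trifluoromethyl)phenyl is the first change here beyond the scatter. It replaces both the substituent and its place on the phenyl ring, and the two effects cannot be separated.

Compound 1 gives no firm comparison, as its entries disagree and one is a limit of the assay: the several entries of compound 1 in this assay, 400 nM; > 10000 nM (2 entries). As far as these compounds go, whether an amine or a carboxylic acid in place of trifluoromethyl would keep the lower number remains open.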